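Methoxy in place of hydrogen on the phenyl ring

The source may report more compounds than this note shows. Statements on the series, on what has been measured and on what is new or still open speak of the compounds shown alone.

Compound 3 `COc1cc(OC)c2c(=O)cc(/C=C/c3ccccc3)oc2c1` is the unsubstituted member of the three measured stilbene-type chromones sharing one core. In a functional assay on SKHep cells (Homo sapiens) for antiproliferative activity, read by MTT assay, with a stated time of 12 h (on this read-out higher numbers stand for weaker inhibition and lower numbers for stronger inhibition), compound 3 gives 26000 nM, the highest of the three numbers, though only the gap to compound 2 lies beyond the scatter. Compound 1 `COc1cc(OC)c2c(=O)cc(/C=C/c3ccc(C(F)(F)F)cc3)oc2c1` gives 20600 nM, and compound 2 `COc1cc(OC)c2c(=O)cc(/C=C/c3ccc(OC(F)(F)F)cc3)oc2c1` gives 12500 nM.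

The two measured steps at the same aromatic carbon are a 1.3-fold higher number from compound 1 to compound 3 (0.10 log units; within the scatter) and a 2.1-fold higher number from compound 2 to compound 3 (0.32 log units; beyond the scatter). Read in the direction of adding a group, trifluoromethyl changed nothing beyond the scatter, while trifluoromethoxy lowered the number modestly.

Compound 4 `COc1ccc(/C=C/c2cc(=O)c3c(OC)cc(OC)cc3o2)cc1` differs from compound 3 by methoxy in place of hydrogen on an aromatic carbon. Methoxy, like trifluoromethoxy, attaches through an oxygen, but the two groups are not identical, so the step from compound 2 to compound 3 is only a partial guide. The expectation for compound 4 is therefore a small step toward a lower number in this assay, most likely within the scatter and at most of the modest size seen for trifluoromethoxy.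

Compound 4 is thus estimated at 16000 nM, within 7000 nM to 32000 nM, an expected step of a 1.6-fold lower number from compound 3 to compound 4 (0.21 log units; within the scatter).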

Compound 4, half-maximal inhibitory concentration: > 40000 nM
Compound 4: a limit, no number (the forecaster's own chance of this, stated with the estimate: 5%); middle value at least 2.5-fold (0.39 log units) away from the limit.
By their numbers in this assay, from the lowest: compounds 2, 1 and 3 (each within the scatter of the next, the first and the last beyond it). At a limit, above all of these: compound 4.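

In this assay compound 4 gives a limit and not a number: the limit of > 40000 nM in this assay, at which 1 of the 4 values shown sits. For the compounds shown here, on this carbon, para to a large group, an oxygen link alone does not carry the lower number of compound 2, since exchanging trifluoromethyl for methyl on that oxygen gives an at least 3.2-fold higher number from compound 2 to compound 4 (0.50 log units; beyond the scatter), the only new step whose floor clears the scatter. The other two steps are an at least 1.5-fold higher number from compound 3 to compound 4 (0.18 log units; that floor lies within the scatter) and an at least 1.9-fold higher number from compound 1 to compound 4 (0.28 log units; that floor lies within the scatter), so methoxy shows no lowering relative to hydrogen or trifluoromethyl, yet neither step establishes a real rise, and the modest gain seen with trifluoromethoxy does not extend to methoxy.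

As far as these compounds go, with only a floor for compound 4, the true size of all three steps stays open, as does the question of whether methoxy differs from hydrogen here at all. Also open, from the compounds shown here alone, is how this carbon responds to groups such as hydroxyl, an amine, a carboxylic acid, chlorine or a longer chain such as ethoxy, and whether the trifluoromethoxy result stands alone or belongs to a wider trend.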